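A few compounds are considered here, and "the series" means these few. Any claim that something is new, unique, unknown or untested is made for them only; others in the source may bear on it.

Among the measured compounds shown here, in an ADME assay on liver for metabolic stability, with Liver microsome (Rattus norvegicus) as the target, read by LC-MS, using microsomes, with a stated time of 5 h (on this read-out higher numbers stand for fast clearance and lower numbers for slow clearance), compound 1 `O[C@H](c1ccccn1)[C@]1(c2cccc(OC(F)(F)F)c2)C[C@@H](O)C1` gives 217 mL/min/kg, the higher of the two numbers so far, while compound 2 `O[C@H](c1ccccn1)[C@]1(c2cccc(C(F)(F)F)c2)C[C@@H](O)C1`, with trifluoromethyl in place of trifluoromethoxy on an aromatic carbon, gives 100 mL/min/kg. That swap is a 2.2-fold lower number from compound 1 to compound 2 (0.34 log units; beyond the scatter), a modest step. Compound 3 `C[C@]1(O)C[C@@](c2cccc(OC(F)(F)F)c2)([C@H](O)c2ccccn2)C1` keeps the trifluoromethoxy group and changes elsewhere: methyl in place of hydrogen on a saturated ring carbon. For the measured compounds named here, no measured step tests this change, so the modest size of a 2.2-fold lower number from compound 1 to compound 2 (0.34 log units; beyond the scatter) is only a loose guide, and a small fall in this assay is tentatively expected. The expected change is a 1.4-fold lower number from compound 1 to compound 3 (0.16 log units; within the scatter). Compound 3 is estimated at 150 mL/min/kg, with an expected range of 70 mL/min/kg to 310 mL/min/kg.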

Compound 3, clearance: 200 mL/min/kg
Compound 3: middle estimate off by 1.3-fold (0.12 log units), on the low side, and the stated range covers the measured number.
By their numbers in this assay, from the lowest: compounds 2, 3 and 1 (each within the scatter of the next, the first and the last beyond it).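

Putting methyl in place of hydrogen on a saturated ring carbon of the four-membered ring gives a 1.1-fold lower number from compound 1 to compound 3 (0.04 log units; within the scatter) in this assay, so clearance does not separate compound 1 from compound 3. At this position, the added methyl leaves the reading within the scatter, whereas the aromatic swap gave a 2.2-fold lower number from compound 1 to compound 2 (0.34 log units; beyond the scatter). No supporting data explain this result. As far as these compounds go, whether a larger group at this ring carbon, such as an ethyl or an amine, would also stay within the scatter remains open.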